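Moving the Methyl Group on the Amide Aryl Ring

A few compounds are considered here, and "the series" means these few. Any claim that something is new, unique, unknown or untested is made for them only; others in the source may bear on it.

In a functional assay on the whole organism (strain Wistar) for inhibition, with Rattus norvegicus as the target, read by paw edema, with a stated time of 1 h, at a dose of 100 mg/kg (on this read-out higher numbers stand for more inhibition at the one dose given (going by the name of the read-out) and lower numbers for less inhibition), three compounds have been measured:

Compound 1 `COc1cc2c(cc1OC)C(CC(=O)O)CC2`: 18.8%
Compound 2 `COc1cc2c(cc1OC)C(CC(=O)Nc1ccc(Br)cc1)CC2`: 50%
Compound 3 `COc1cc2c(cc1OC)C(CC(=O)Nc1ccccc1C)CC2`: 21.9%

Compound 3 sits second of the three; its nearest neighbour is compound 1, with a number 3.1 percentage points higher from compound 1 to compound 3 (within the scatter), and its furthest is compound 2, with a number 28.1 percentage points lower from compound 2 to compound 3 (beyond the scatter).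

Compound 4 `COc1cc2c(cc1OC)C(CC(=O)Nc1ccc(C)cc1)CC2` differs from compound 3 by 4-methylphenyl in place of 2-methylphenyl on an amide-type nitrogen. Among the compounds with values here, no measured step isolates this change. The step of a number 28.1 percentage points lower from compound 2 to compound 3 (beyond the scatter) bears on it, but there both the group and its place on the ring changed, and a number 31.2 percentage points higher from compound 1 to compound 2 (beyond the scatter) shows how much a 4-bromophenyl amide adds over the acid. A modest rise is therefore expected for compound 4, a number 11.1 percentage points higher from compound 3 to compound 4 (beyond the scatter), with real uncertainty. The estimate for compound 4 is 33%, within 15% to 52%.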

Compound 4, a percentage reported as inhibition, in the whole organism at one dose (the size of the read-out at that dose, not a potency): 34.4%
The estimate for compound 4 lay 1.4 percentage points below the measured number; the range from low to high includes it.
By their numbers in this assay, from the lowest: compounds 1 and 3 (each within the scatter of the next); then compound 4; then compound 2.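

Moving the methyl group alone, with the same atoms joined differently, changes the result in this assay (a number 12.5 percentage points higher from compound 3 to compound 4 (beyond the scatter)). With 4-methylphenyl on the amide-type nitrogen, the amide now stands clear of the acid (a number 15.6 percentage points higher from compound 1 to compound 4 (beyond the scatter)), yet methyl in place of bromo on an aromatic carbon still gives a lower number (a number 15.6 percentage points lower from compound 2 to compound 4 (beyond the scatter)). No measured evidence is available to explain these differences.

As far as these compounds go, what remains open is how an unsubstituted phenyl ring on the amide-type nitrogen would compare. Also open, from the compounds shown here alone, is whether a chloro or methoxy group in place of the methyl on an aromatic carbon would read closer to the bromo compound.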